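This account rests on a few compounds, and the source may have more. Where it says the series, first, only, none or still open, it means among the compounds named here.

Compound 1 `N#Cc1ccc(Nc2cnccc2SCCCCCC(=O)O)c2ccccc12`: 4240 nM
Compound 2 `N#Cc1ccc(Oc2cnccc2SCCCC(=O)O)c2ccccc12`: 1230 nM
Compound 3 `N#Cc1ccc(Oc2cnccc2SCCCCCC(=O)O)c2ccccc12`: 4740 nM

All three numbers come from an assay on HEK293 cells for inhibition of solute carrier family 22 member 12 (Homo sapiens), read by scintillation counting, with stated times of 30 min and 15 min; on this read-out higher numbers stand for weaker inhibition and lower numbers for stronger inhibition. Compound 3 holds the highest number of the three; compound 1 lies within the scatter of it, and compound 2 sits clearly lower. Compound 4 `N#Cc1ccc(Oc2cnccc2SCCCCCCC(=O)O)c2ccccc12` is built from compound 3 by one change: carboxymethyl in place of carboxy on a saturated chain carbon, five bonds along the chain from a sulfur. Among the compounds with values here, the only measured step that bears on this change is the earlier chain lengthening, a 3.9-fold higher number from compound 2 to compound 3 (0.59 log units; beyond the scatter), a modest rise beyond the scatter. Adding one more chain carbon is therefore expected to push the number in the same direction, or at most leave it flat. Compound 4 is expected to show a 1.5-fold higher number from compound 3 to compound 4 (0.17 log units; within the scatter) in this assay. Compound 4 is estimated at 7000 nM, with a range from 3000 nM to 18000 nM.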

Compound 4, half-maximal inhibitory concentration: 3780 nM
Compound 4: middle estimate off by 1.9-fold (0.27 log units), on the high side; the range from low to high includes it.
By their numbers in this assay, from the lowest: compound 2; then compounds 4, 1 and 3 (each within the scatter of the next).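

In this assay, carboxymethyl in place of carboxy, five bonds along the chain from a sulfur, gives a 1.3-fold lower number from compound 3 to compound 4 (0.10 log units; within the scatter), so the rise of a 3.9-fold higher number from compound 2 to compound 3 (0.59 log units; beyond the scatter) does not carry on at this position. The longer chain still leaves a 3.1-fold higher number from compound 2 to compound 4 (0.49 log units; beyond the scatter), which sets the shorter chain of compound 2 apart from both longer ones. No evidence is available to explain these steps.

On these data alone, what stays open is whether a still longer chain holds this level, and whether a chain shorter than that of compound 2 goes lower. Also open, as far as these compounds go, is how an amide or a tetrazole would fare in place of the carboxylic acid.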